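This account rests on a few compounds, and the source may have more. Where it says the series, first, only, none or still open, it means among the compounds named here.

Among the measured compounds shown here, in a functional assay on RKO cells (Homo sapiens) for cytotoxicity, read by resazurin assay, with a stated time of 72 h (on this read-out lower numbers stand for stronger inhibition and higher numbers for weaker inhibition), compound 3 `COc1ccc(Nc2nc(-n3c(C)nc4ccccc43)cs2)cc1` gives 25 nM, the only number so far. Compound 1 `Brc1ccc(Nc2nc(-n3cnc4ccccc43)cs2)cc1` stands at > 100000 nM, which is a limit. Compound 2 `c1ccc(Nc2nc(-n3cnc4ccccc43)cs2)cc1`, which has no methoxy group either, stands at > 100000 nM, again a limit. Compound 4 `COc1ccc(Nc2nc(-n3cnc4ccccc43)cs2)cc1` comes from compound 3 by hydrogen in place of methyl on an aromatic carbon, between two ring nitrogen atoms. Compound 4 keeps the methoxy group, while compound 1 and compound 2 share its hydrogen at this place. For the measured compounds named here, the only measured step, a step that the two limits leave unreadable from compound 1 to compound 2, gives no size to carry over. Going by the values given here, no measured pair isolates this methyl. Weaker inhibition is expected, with an estimated 100-fold higher number from compound 3 to compound 4 (2.00 log units; beyond the scatter). Compound 4 is estimated at 2500 nM, with an expected range of 100 nM to 60000 nM.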

Compound 4, half-maximal inhibitory concentration: > 100000 nM
Compound 4: a limit, no number (the forecaster's own chance of this, stated with the estimate: 30%); middle value at least 40-fold (1.60 log units) from the limit.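

In this assay, among the compounds shown here, the methyl between two ring nitrogen atoms proves decisive, and this is the first pair to isolate that position (an at least 4000-fold higher number from compound 3 to compound 4 (3.60 log units; beyond the scatter)). Compound 4 stands at a limit, not a number (> 100000 nM). Keeping the methoxy group does not hold the activity of compound 3 once this methyl is gone.

From the compounds shown here alone, whether an ethyl group or an amine at this place would hold that activity remains open. The steps among compound 1, compound 2 and compound 4 cannot be read, so what methoxy adds without the methyl also stays open: the limit of > 100000 nM in this assay, at which 3 of the 4 values shown sit.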